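The source may report more compounds than this note shows. Statements on the series, on what has been measured and on what is new or still open speak of the compounds shown alone.

Among the compounds with values here, compound 1 `C[C@@H](NCC1CCN(CCCc2c[nH]c3ccc(-n4cnnc4)cc23)CC1)c1ccccc1` is one of three compounds measured in an assay on CHO cells for displacement of a labelled ligand from 5-hydroxytryptamine receptor 1B (Homo sapiens) (on this read-out lower numbers stand for stronger inhibition and higher numbers for weaker inhibition), where compound 1 gives 14 nM. Among those three numbers compound 1 stands second highest: compound 3 `CC(=O)Nc1ccc([C@@H](C)NCC2CCN(CCCc3c[nH]c4ccc(-n5cnnc5)cc34)CC2)cc1` gives 8.9 nM, and compound 2 `C[C@@H](NC1CCN(CCCc2c[nH]c3ccc(-n4ccnc4)cc23)CC1)c1ccccc1` gives 110 nM. Within the data shown here, the one step recorded between compounds that differ in a single place, a 1.6-fold lower number from compound 1 to compound 3 (0.20 log units; within the scatter), adds acetamido in place of hydrogen on an aromatic carbon and leaves the number essentially where it was.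

Compound 4 `CN(Cc1ccco1)C1CCN(CCCc2c[nH]c3ccc(-n4cnnc4)cc23)CC1` differs from compound 1 in another way altogether: ((furan-2-yl)methyl)(methyl)amino in place of ((1-phenylethyl)amino)methyl on a saturated ring carbon. Among the measured compounds shown here, no measured step covers this change. Compound 2 also carries its amine directly on the saturated ring carbon, but it differs from compound 1 in a second place as well, so its values can only be noted, not read as a step. The step from compound 1 to compound 3 says nothing about this part of the molecule. Given that compound 2, the only other compound with a directly attached amine, sits well higher than compound 1, the step from compound 1 to compound 4 is expected to be a moderate rise, a 5.0-fold higher number from compound 1 to compound 4 (0.70 log units; beyond the scatter). Compound 4 is therefore estimated at 70 nM, within a range from 20 nM to 250 nM.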

Compound 4, half-maximal inhibitory concentration: 89 nM
For compound 4 the middle estimate is 1.3-fold (0.10 log units) below the measured one, within the range that was stated.
By their numbers in this assay, from the lowest: compounds 3 and 1 (each within the scatter of the next); then compounds 4 and 2 (each within the scatter of the next).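

Within the data shown here, the change on the saturated ring carbon of the six-membered ring is the first step read at this position, and in this assay it gives a 6.4-fold higher number from compound 1 to compound 4 (0.80 log units; beyond the scatter). Unlike the acetamido step on the aromatic carbon, which stayed within the scatter, this change moves the number beyond it. Several features change together, with a five-membered aromatic ring with 1 hetero atom replacing a six-membered aromatic ring of carbon only, the hydrogen-bond donor going and the defined stereocentre going, and nothing measured here explains the rise.

Which of these features the rise follows remains open. So does how a benzyl(methyl)amino group or a ((pyridin-2-yl)methyl)(methyl)amino group would read at this same place on the core of compound 1.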